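Nitro for methylsulfonyl on the amide aryl ring

The source may report more compounds than this note shows. Statements on the series, on what has been measured and on what is new or still open speak of the compounds shown alone.

Measured compounds:
Compound 1 `COc1ccc(C(=O)N2CCC(n3cncc3-c3ccc(OS(=O)(=O)c4cccc5cnccc45)cc3)CC2)cc1` — 64 nM
Compound 2 `CS(=O)(=O)c1ccc(C(=O)N2CCC(n3cncc3-c3ccc(OS(=O)(=O)c4cccc5cnccc45)cc3)CC2)cc1` — 0.32 nM

In an assay on THP-1 cells for antagonist activity at P2X purinoceptor 7 (Homo sapiens), read by ELISA, with a stated time of 30 min (a higher number here means a weaker inhibitor, a lower number a stronger inhibitor), compound 1 gives 64 nM and compound 2 gives 0.32 nM. Going by the values given here, the only step among the measured compounds is a 200-fold lower number from compound 1 to compound 2 (2.30 log units; beyond the scatter), a large change of a single substituent on the amide aryl ring. Compound 2 therefore stands at the lowest number of the two, well apart from compound 1.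

Compound 3 `O=C(c1ccc([N+](=O)[O-])cc1)N1CCC(n2cncc2-c2ccc(OS(=O)(=O)c3cccc4cnccc34)cc2)CC1` has not been measured. It differs from compound 2 by nitro in place of methylsulfonyl on an aromatic carbon. Among the compounds with values here, no measured step shows this exact change, so the only guide is that compound 2 carries a methylsulfonyl at this position and reaches 0.32 nM, while the methoxy of compound 1 sits far higher. Both the leaving and the entering group carry two hydrogen-bond acceptors and no donor, so compound 3 is expected to stay close to compound 2, with the step estimated as a 3.1-fold higher number from compound 2 to compound 3 (0.49 log units; beyond the scatter), well inside the room between the two measured values. For compound 3 in this assay an estimate of 1 nM is given, within a range from 0.2 nM to 5 nM.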

Compound 3, half-maximal inhibitory concentration: 8.29 nM
For compound 3 the middle estimate is 8.3-fold (0.92 log units) below the measured one; measured number above the stated range.
By their numbers in this assay, from the lowest: compound 2; then compound 3; then compound 1.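

In this assay, this position on the amide aryl ring separates methylsulfonyl from nitro, even though both groups are counted with two hydrogen-bond acceptors and no donor: the exchange gives a 26-fold higher number from compound 2 to compound 3 (1.41 log units; beyond the scatter), so that shared count does not keep the values together. Nitro is also not equivalent to methoxy, with a 7.7-fold lower number from compound 1 to compound 3 (0.89 log units; beyond the scatter), which places the three groups in a graded order, with methylsulfonyl lowest, nitro in the middle and methoxy highest, rather than leaving methylsulfonyl alone against a single higher level. Nothing available explains this order.

The compounds shown leave open how other groups at this place would rank, for example a primary sulfonamide, a nitrile, a carboxylic acid or an amine, and whether a longer alkyl chain on the sulfonyl group would keep the low value of compound 2. They also leave open whether the same order would hold with these groups elsewhere on the aryl ring, since all three compounds carry their group para to the large group.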